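A few compounds are considered here, and "the series" means these few. Any claim that something is new, unique, unknown or untested is made for them only; others in the source may bear on it.

Compound 2 `O=[N+]([O-])c1cccc(CNc2cc(Br)cc3[nH]ncc23)c1`: 7950 nM
Compound 1 `O=C1NC(=O)c2c(NCc3ccccc3[N+](=O)[O-])cccc21`: > 100000 nM

Among the measured compounds shown here, in an assay for inhibition of Indoleamine 2,3-dioxygenase 1 (Homo sapiens), with stated times of 10 min and 60 min (a lower number here means a stronger inhibitor, a higher number a weaker inhibitor), compound 2 gives 7950 nM, the only number among the two values shown. Compound 1 sits at the limit of > 100000 nM in this assay, at which 1 of the 2 values shown sits, which is a limit of the assay and not a number. Compound 3 `O=[N+]([O-])c1cccc(CNc2cc(C(F)(F)F)cc3[nH]ncc23)c1` differs from compound 2 by trifluoromethyl in place of bromo on an aromatic carbon. For the measured compounds named here, no step between measured compounds is available to guide this change, so no shift beyond the usual scatter is expected in this assay. Compound 3 is expected to give 8000 nM in this assay, between 3000 nM and 25000 nM. That estimate means a 1.0-fold higher number from compound 2 to compound 3 (0.00 log units; within the scatter), a step expected to stay within the scatter.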

Compound 3, half-maximal inhibitory concentration: > 100000 nM
Compound 3: no number, only a limit (the forecaster's own chance of this, stated with the estimate: 10%); middle value at least 12-fold (1.09 log units) from the limit.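

In this assay, among the compounds shown here, the aromatic carbon carrying bromo proves sensitive to its substituent: trifluoromethyl in place of bromo gives an at least 12-fold higher number from compound 2 to compound 3 (1.09 log units; beyond the scatter) as the first one-place comparison. With bromo the shared core keeps a measurable value, and with trifluoromethyl that value is lost. Compound 3 stands at a limit of the assay, not a number: the limit of > 100000 nM in this assay, at which 2 of the 3 values shown sit.

Going by these compounds, how far compound 3 lies past that limit remains open. So does whether chloro, methyl or an amine on this carbon would keep a measurable value.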